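Three Close Analogues and a Fourth Still to Measure

This account rests on a few compounds, and the source may have more. Where it says the series, first, only, none or still open, it means among the compounds named here.

Compound 1 `Nc1ccccc1NC(=O)c1ccc(CSC(=S)N2CCc3ccccc32)cc1` gives 25.7% in a functional assay on A-375 cells (Homo sapiens) for antiproliferative activity, read by CCK-8 assay, with a stated time of 72 h, tested at 2 uM; on this read-out higher numbers stand for a stronger effect at the one concentration tested and lower numbers for a weaker effect. Compound 2 `CN(C(=S)SCc1ccc(C(=O)Nc2ccccc2N)cc1)c1cccnc1` gives 26.5%. Compound 3 `COc1ccc(N2CCN(C(=S)SCc3ccc(C(=O)Nc4ccccc4N)cc3)CC2)cc1` gives 28.1%.

Among the compounds with values here, of the three numbers, the one for compound 2 is the second highest, with compound 1 nearest and compound 3 furthest; all three lie within the scatter of one another, so none can be called more or less active than another. Compound 4 `Nc1ccccc1NC(=O)c1ccc(CSC(=S)N2CCCc3ccccc32)cc1` has not been measured. The change is 1,2,3,4-tetrahydroquinolin-1-yl in place of methyl(pyridin-3-yl)amino on a thiocarbonyl carbon. Within the data shown here, the one measured step at that place, a number 0.8 percentage points higher from compound 1 to compound 2 (within the scatter), stayed within the scatter, and compound 1 carries the related 2,3-dihydro-1H-indol-1-yl there. The step of a number 0.5 percentage points lower from compound 2 to compound 4 (within the scatter) is therefore expected to stay within the scatter. Compound 4 is estimated to give 26%, in the range 16% to 36%.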

Compound 4, a percentage reported as inhibition, at one concentration (the size of the read-out at that concentration, not a potency): 26.5%
Compound 4: middle estimate off by 0.5 percentage points, on the low side; the range from low to high includes it.
By their numbers in this assay, from the lowest: compounds 1, 2, 4 and 3 (each within the scatter of the next).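

Putting 1,2,3,4-tetrahydroquinolin-1-yl in place of methyl(pyridin-3-yl)amino on the thiocarbonyl carbon gives no change at the digits printed from compound 2 to compound 4 (within the scatter) in this assay, although the entering group has more heavy atoms and an aromatic ring of carbon only. Set against 2,3-dihydro-1H-indol-1-yl, the same group gives a number 0.8 percentage points higher from compound 1 to compound 4 (within the scatter), so neither change at this position separates the compounds. Nothing available explains this flat result.

On these data alone, whether a small open-chain group such as dimethylamino, or a group carrying a carboxylic acid, would move the number beyond the scatter remains open.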